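Swapping benzylamino for methyl on a carbonyl carbon

The compounds below may be only part of what the source reports. "The series", "measured", "known", "first", "only" and "open" are said of these compounds alone.

- compound 1 `C[C@@H](NC(=O)Nc1ccc2c(Cl)c(OCCSC(=N)N)oc(=O)c2c1)c1ccccc1` gives 1.03 h
- compound 2 `N=C(N)SCCCOc1oc(=O)c2cc(NC(=O)NCc3ccccc3)ccc2c1Cl` gives 2.47 h
- compound 3 `N=C(N)SCCOc1oc(=O)c2cc(NC(=O)CCc3ccccc3)ccc2c1Cl` gives 0.65 h

These numbers come from an ADME assay for pharmacokinetics (on this read-out lower numbers stand for a shorter-lived compound and higher numbers for a longer-lived compound), and compound 2 sits at the top: its 2.47 h stands beyond the scatter from both other compounds. Compound 4 `CC(=O)Nc1ccc2c(Cl)c(OCCCSC(=N)N)oc(=O)c2c1` has not been measured yet. Set against compound 2, it shows (methyl in place of benzylamino on a carbonyl carbon). Among the measured compounds shown here, the only measured change at such a carbonyl carbon, phenethyl in place of (1-phenylethyl)amino, gave a 1.6-fold lower number from compound 1 to compound 3 (0.20 log units; within the scatter) and no more, so a small downward move is expected here too. That guide is weak, since phenethyl still carries a six-membered aromatic ring of carbon only, while this new change removes one. The expected step is a 1.4-fold lower number from compound 2 to compound 4 (0.14 log units; within the scatter) on this estimate, and it need not leave the scatter. For compound 4 the expected value is 1.8 h within an estimated range of 0.7 h to 4.5 h in this read-out.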

Compound 4, half-life: 1.13 h
Beside the measured number, compound 4's estimate is 1.6-fold (0.20 log units) above it, within the range that was stated.
By their numbers in this assay, from the lowest: compounds 3, 1 and 4 (each within the scatter of the next); then compound 2.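

In this assay, this change at the carbonyl carbon gives a 2.2-fold lower number from compound 2 to compound 4 (0.34 log units; beyond the scatter). Among the compounds shown here, it is a modest step, but it shows that this place can affect the read-out beyond the scatter, whereas the only earlier step at such a carbon, a 1.6-fold lower number from compound 1 to compound 3 (0.20 log units; within the scatter), stayed within it. The change removes the benzylamino group's six-membered aromatic ring and its hydrogen-bond donor together, and nothing measured here gives a reason for the shorter half-life.

The shared step cannot show how much of the drop belongs to the ring and how much to the nitrogen that carries the donor. It also leaves open where an ethylamino group, a plain phenyl ring or a longer alkyl chain on the same carbonyl carbon would fall relative to compound 2 and compound 4.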